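A few compounds are considered here, and "the series" means these few. Any claim that something is new, unique, unknown or untested is made for them only; others in the source may bear on it.

Measured compounds:
- Compound 1 `N#CC1=C(N)Oc2c(c3nc4ccccc4nc3c3ccccc23)C12C(=O)N(Cc1cnnn1-c1cccc(Br)c1)c1ccccc12` — in a functional assay on HepG2 cells (Homo sapiens) for antiproliferative activity, read by MTT assay, with a stated time of 48 h (on this read-out lower numbers stand for stronger inhibition and higher numbers for weaker inhibition), compound 1 gives > 50000 nM, a limit of the assay.
- Compound 2 `CCOc1ccc(-n2nncc2CN2C(=O)C3(C(C#N)=C(N)Oc4c3c3nc5ccccc5nc3c3ccccc43)c3ccccc32)cc1` — in this assay compound 2 gives > 50000 nM, a limit of the assay.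
- Compound 3 `Cc1ccc(-n2nncc2CN2C(=O)C3(C(C#N)=C(N)Oc4c3c3nc5ccccc5nc3c3ccccc43)c3ccccc32)cc1Cl` — in this assay compound 3 gives > 50000 nM, a limit of the assay.

Compound 3 stands at a limit only, and so do the other two values shown; all three sit at the limit of > 50000 nM in this assay, at which 3 of the 3 values shown sit. No value in the series has been read as a number.

Compound 4 `N#CC1=C(N)Oc2c(c3nc4ccccc4nc3c3ccccc23)C12C(=O)N(Cc1cnnn1-c1cc(Cl)ccc1Cl)c1ccccc12` differs from compound 3 in one place: 2,5-dichlorophenyl in place of 3-chloro-4-methylphenyl on an aromatic nitrogen. The measured steps that bear on this change are those that exchange the aryl group on the same aromatic nitrogen: a step that the two limits leave unreadable from compound 1 to compound 2, a step that the two limits leave unreadable from compound 1 to compound 3 and a step that the two limits leave unreadable from compound 2 to compound 3. Each of them is unreadable in size, since both ends sit at the limit.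

Nothing in these steps points to a readable change in this assay in either direction; the expectation is that compound 4 also remains at the limit. Compound 4 is therefore expected to give 50000 nM in this assay, with a range from 20000 nM to 100000 nM. The step from compound 3 to compound 4 is expected to be a number no higher from compound 3 to compound 4 (the limit leaves the size open), meaning none beyond the scatter.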

Compound 4, half-maximal inhibitory concentration: > 50000 nM
Compound 4 was reported as a limit; the forecaster's own chance of this, stated with the estimate: 85%; the middle value lies on the limit itself.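

Compound 4 gives > 50000 nM in this assay, a limit and not a number. No step among compound 1, compound 2, compound 3 and compound 4 can be read, since all sit at the same limit: the limit of > 50000 nM in this assay, at which 4 of the 4 values shown sit.

The compounds shown leave open whether any aryl group on this aromatic nitrogen gives a readable value in this assay, and how far these four compounds differ.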